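The source may report more compounds than this note shows. Statements on the series, on what has been measured and on what is new or still open speak of the compounds shown alone.

Compound 1 `Cc1ccc(CSc2cc(Cl)c(C)cc2S(=O)(=O)/N=C(\N)n2nc(C)cc2-c2ccccc2)cc1` was tested in a functional assay on HeLa cells (Homo sapiens) for cytotoxicity, read by MTT assay, with a stated time of 72 h (a higher number here means a weaker inhibitor, a lower number a stronger inhibitor), where compound 1 gives 62000 nM, the highest of the three numbers in hand. Compound 3 `Cc1ccc(CSc2cc(Cl)c(C)cc2S(=O)(=O)/N=C(\N)n2nccc2-c2ccccc2)cc1` gives 17000 nM in this assay, and compound 2 `Cc1cc(S(=O)(=O)/N=C(\N)n2nccc2-c2ccccc2)c(SCc2ccccc2)cc1Cl` gives 5000 nM. The step of a 3.6-fold lower number from compound 1 to compound 3 (0.56 log units; beyond the scatter) and the step of a 3.4-fold higher number from compound 2 to compound 3 (0.53 log units; beyond the scatter) are both modest and both beyond the scatter. Compound 4 `Cc1cc(-c2ccccc2)n(/C(N)=N/S(=O)(=O)c2cc(C)c(Cl)cc2SCc2ccc(Cl)cc2)n1` differs from compound 1 in one place: chloro in place of methyl on an aromatic carbon. Neither measured step covers a swap of methyl for chloro; the nearest is the step from compound 2 to compound 3, which concerns a methyl entering on that same ring, and it is only modest in size. Within the data shown here, with no step that bears directly, the expectation is that the change in this assay stays small, most likely within the scatter, and the estimated step is a 1.2-fold lower number from compound 1 to compound 4 (0.09 log units; within the scatter). Compound 4 is therefore expected to give about 50000 nM in this assay, within a range from 20000 nM to 150000 nM.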

Compound 4, half-maximal inhibitory concentration: 3000 nM
Estimate against measurement, compound 4: 17-fold (1.22 log units) above; measured number outside the range, below it.
By their numbers in this assay, from the lowest: compounds 4 and 2 (each within the scatter of the next); then compound 3; then compound 1.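

In this assay, the exchange of 4-methylbenzyl for 4-chlorobenzyl gives a 21-fold lower number from compound 1 to compound 4 (1.32 log units; beyond the scatter), a large step from replacing one heavy atom with another while the counts of hydrogen-bond donors and acceptors stay the same. The earlier step at this place, a 3.4-fold higher number from compound 2 to compound 3 (0.53 log units; beyond the scatter), was only modest and concerned methyl in place of hydrogen, so this position can shift the number much further than that step alone suggested. Nothing available bears on the reason for the size of this step.

As far as these compounds go, it remains open whether chloro has a step of similar size on the core of compound 3, which lacks the methyl removed in the step of a 3.6-fold lower number from compound 1 to compound 3 (0.56 log units; beyond the scatter). From the compounds shown here alone, how fluoro, methoxy or an amine at this place would compare with chloro also remains open.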